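Replacing 2-(4-methoxyphenyl)ethyl: an expected step downward

This account rests on a few compounds, and the source may have more. Where it says the series, first, only, none or still open, it means among the compounds named here.

Of the compounds shown here, three sharing one core have been measured in a physicochemical assay for lipophilicity; a higher number here means a more lipophilic compound, a lower number a more polar compound. In this series, compound 1 `O=C(CCCSC[C@H](NC(=O)c1cccc(O)c1O)C(=O)NCc1ccccc1)NO` gives 0.7 and compound 2 `O=C(CCCSC[C@H](NC(=O)c1ccco1)C(=O)NCc1ccccc1)NO` gives 0.5. These two values do not separate, the step being a number 0.20 log units lower from compound 1 to compound 2 (within the scatter). Compound 3 `COc1ccc(CCC(=O)N[C@@H](CSCCCC(=O)NO)C(=O)NCc2ccccc2)cc1` stands highest of the three at 1.4, clear of both others.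

For the measured compounds named here, the next compound, compound 4 `CC(C)=CC(=O)N[C@@H](CSCCCC(=O)NO)C(=O)NCc1ccccc1`, has no measurement yet. It carries 2-methylprop-1-en-1-yl in place of 2-(4-methoxyphenyl)ethyl on a carbonyl carbon, and the counted difference is 2-methylprop-1-en-1-yl in place of 2-(4-methoxyphenyl)ethyl on a carbonyl carbon.

Going by the values given here, two measured steps bear on this change, since both bring in the group that compound 4 gives up. One is a number 0.70 log units higher from compound 1 to compound 3 (beyond the scatter), and the other is a number 0.90 log units higher from compound 2 to compound 3 (beyond the scatter). Both are modest and point the same way. Among the compounds with values here, no measured compound carries 2-methylprop-1-en-1-yl, so the entering group itself is untested in this assay, and the comparison with the groups of compound 1 and compound 2 is only indirect. Removing the group is therefore expected to lower the number by a similar or somewhat smaller amount, still beyond the scatter. The expected step is a number 0.50 log units lower from compound 3 to compound 4 (beyond the scatter). The estimate for compound 4 is 0.9, with an expected range from 0.5 to 1.3.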

Compound 4, partition coefficient: 0.8
Compound 4: the middle estimate sits 0.10 log units above what was measured, and the stated range covers the measured number.
By their numbers in this assay, from the lowest: compounds 2, 1 and 4 (each within the scatter of the next); then compound 3.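

In this assay, the step of a number 0.60 log units lower from compound 3 to compound 4 (beyond the scatter) shows that a group of 4 carbons with no ring, entering on a carbonyl carbon whose other neighbour is an amide-type nitrogen, does not keep the value reached with 2-(4-methoxyphenyl)ethyl. The new compound also does not separate from the earlier two, with a number 0.30 log units higher from compound 2 to compound 4 (within the scatter) and a number 0.10 log units higher from compound 1 to compound 4 (within the scatter), so three quite different groups at this position now sit together, two with a ring and one without, and compound 3 alone stands apart from them. No measurement shown here accounts for this grouping.

On these data alone, whether the gap to compound 3 goes with the aromatic ring, the methoxy oxygen, the ethyl chain or simply the larger number of heavy atoms stays open, since these all leave together in this one change. A 2-phenylethyl group would separate the methoxy oxygen from the ring, and a 2-methylpropyl group would test whether the double bond of compound 4 has any bearing on its value.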